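The source may report more compounds than this note shows. Statements on the series, on what has been measured and on what is new or still open speak of the compounds shown alone.

Compound 1, `O=C(NCc1cccc(Cl)c1)c1ccc2cn(CCN3CCOC3=O)nc2c1`, gives 220 nM in an assay on isolated protein for inhibition of thyroid hormone receptor beta (Homo sapiens), read by fluorescence, with a stated time of 30 min; a lower number here means a stronger inhibitor, a higher number a weaker inhibitor.
Compound 2, `O=C(NCc1cccc(Cl)c1)c1cc(Cl)c2cn(CCn3cccn3)nc2c1`, gives 225 nM in this assay.
Compound 3, `CCCN(CC1CCOC1)C(=O)c1cc(Cl)c2oc(NCc3cccc(Cl)c3)nc2c1`, gives 71 nM in this assay.

Of these three, compound 3 has the lowest number, and the gaps from it to compound 1 and to compound 2 both lie beyond the usual scatter of repeated measurements, so compound 3 is the strongest inhibitor here. Compound 4, `CCCc1cc(C(=O)N(CCC)CC2CCOC2)cc2nc(NCc3cccc(Cl)c3)oc12`, keeps the whole of compound 3 except for one change: propyl in place of chloro on an aromatic carbon. For the measured compounds named here, no measured pair shows this exchange, so there is nothing to lean on directly. A change of this kind is expected to shift the number only a little, with the step of a 1.3-fold higher number from compound 3 to compound 4 (0.10 log units; within the scatter) likely to stay within or near the scatter. Compound 4 is therefore estimated at 90 nM, with a plausible range from 30 nM to 300 nM.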

Compound 4, half-maximal inhibitory concentration: 957 nM
The estimate for compound 4 lay 11-fold (1.03 log units) below the measured number; measured number above the stated range.
By their numbers in this assay, from the lowest: compound 3; then compounds 1 and 2 (each within the scatter of the next); then compound 4.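

In this assay, this aromatic carbon proves sensitive: propyl in place of chloro gives a 13-fold higher number from compound 3 to compound 4 (1.13 log units; beyond the scatter), a weakening well beyond the usual scatter. For the compounds shown here, the earlier compounds offered no single-change pair, so this is the first sign that one substituent on this core can matter so much. Nothing shown gives a reason for the size of this step.

Going by these compounds, whether methyl or ethyl at this carbon would stay near compound 3 remains open. So does whether fluoro or methoxy would be tolerated there.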